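The source may hold more compounds than are shown below. What is called first, only, known or untested is meant among the compounds shown, and "the series" means these compounds.

In a functional assay on A549 cells (Homo sapiens) for cytotoxicity, read by MTT assay, with a stated time of 48 h (on this read-out lower numbers stand for stronger inhibition and higher numbers for weaker inhibition), the shared core carrying a benzyl-substituted triazole, compound 1 `O=c1ccoc2cc(OCc3cn(Cc4ccccc4)nn3)ccc12`, gives only a limit, > 100000 nM. Compound 2 `O=c1ccoc2cc(OCc3cn(Cc4cccc(Br)c4)nn3)ccc12`, which carries bromo in place of hydrogen on an aromatic carbon, likewise gives a limit, > 100000 nM. Among the measured compounds shown here, compound 3 `O=c1ccoc2cc(OCc3cn(Cc4cccc(Cl)c4)nn3)ccc12`, with chloro on that aromatic carbon, is the only compound to give a number, 13700 nM, so it is the one point on which a comparison can rest; the two other values sit at the limit of > 100000 nM in this assay, at which 2 of the 3 values shown sit.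

The change to compound 4 `O=c1ccoc2cc(OCc3cn(Cc4ccccc4Br)nn3)ccc12` is 2-bromophenyl in place of 3-chlorophenyl on a saturated chain carbon bound to an aromatic nitrogen. For the measured compounds named here, two measured steps bear on it. Going an at least 7.2-fold lower number from compound 1 to compound 3 (0.86 log units; beyond the scatter) shows chloro lowering the number, and going an at least 7.2-fold lower number from compound 2 to compound 3 (0.86 log units; beyond the scatter) shows the same when chloro replaces bromo. The step that the two limits leave unreadable from compound 1 to compound 2 gives no size. Both readable steps therefore point the same way: bromo on the phenyl ring sits at the limit, chloro alone produces a number. Compound 4 returns to bromo, though on a different carbon of the ring, so the number is expected to rise rather than fall, with a real chance of another limit. Compound 4 is estimated at 60000 nM, with a range from 15000 nM to 250000 nM. That estimate means an expected step of a 4.4-fold higher number from compound 3 to compound 4 (0.64 log units; beyond the scatter).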

Compound 4, half-maximal inhibitory concentration: > 100000 nM
Compound 4: a limit, no number; the forecaster's own chance of this, stated with the estimate: 50%; middle value at least 1.6-fold (0.22 log units) away from the limit.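

Among the compounds shown here, the change from 3-chlorobenzyl to 2-bromobenzyl in this assay gives an at least 7.2-fold higher number from compound 3 to compound 4 (0.86 log units; beyond the scatter), so the only number is not kept when this group is exchanged. Bromo now gives no number in either of the two forms shown, the 3-bromophenyl of compound 2 and the 2-bromophenyl of compound 4, whereas the earlier compounds showed this for the 3-bromophenyl form alone. The steps among compound 1, compound 2 and compound 4 cannot be read, and no order among these three can be given, because each of them gives only a limit: the limit of > 100000 nM in this assay, at which 3 of the 4 values shown sit.

The step from compound 3 to compound 4 changes the halogen and its place on the ring together, so the compounds shown cannot say which of the two matters, and a 2-chlorophenyl group would be needed to separate them. Going by these compounds, it also remains open how a methoxy group, a trifluoromethyl group or an amine on the benzyl ring would compare with the 3-chlorophenyl of compound 3.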